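Changing the Side Chain of Compound 1 to a Thioether

This account rests on a few compounds, and the source may have more. Where it says the series, first, only, none or still open, it means among the compounds named here.

Compound 1 `CC(C)[C@H](NC(=O)CN(c1nc(Cl)nc2[nH]cnc12)C1CC1)C(=O)OCc1ccccc1` was tested in a functional assay on the whole organism (Tail, strain ICR) with Mus musculus as the target, in the tail flick test, with a stated time of 60 min, at a dose of 25 umol/kg by the oral route (a lower number here means a weaker effect, a higher number a stronger effect of the compound at the dose given), where compound 1 gives 55.5%. Among the compounds with values here, its only measured companion is compound 2 `CC(C)[C@H](NC(=O)CN(c1nc(Cl)nc2[nH]cnc12)C1CC1)C(=O)O`, which in this assay gives 38.8%. Within the data shown here, the single step between measured compounds, a number 16.7 percentage points lower from compound 1 to compound 2 (beyond the scatter), sits at the ester end of the molecule, far from the side chain on the amino-acid portion. On the two numbers shown, compound 1 stands highest, and its step to compound 2 lies beyond the scatter.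

Compound 3 `CSCC[C@H](NC(=O)CN(c1nc(Cl)nc2[nH]cnc12)C1CC1)C(=O)OCc1ccccc1` differs from compound 1 in one place: 2-(methylsulfanyl)ethyl in place of isopropyl on a saturated chain carbon bound to an amide-type nitrogen and a carbonyl carbon. Of the measured steps, none touches this position; the change on the ester oxygen tells nothing about the side chain carbon. Without a comparable step, the expectation rests only on the shared core and the unchanged benzyl ester, so the change is expected to be a number 5.5 percentage points lower from compound 1 to compound 3 (within the scatter), that is, no step beyond the usual scatter. Compound 3 is therefore estimated to give 50% in this assay, within a range from 30% to 72%.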

Compound 3, a percentage reported as activity, at one dose (the size of the read-out at that dose, not a potency): 30.8%
The estimate for compound 3 lay 19.2 percentage points above the measured number, within the range that was stated.
By their numbers in this assay, from the lowest: compounds 3 and 2 (each within the scatter of the next); then compound 1.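

In this assay, the group on the saturated chain carbon bound to an amide-type nitrogen and a carbonyl carbon proves to matter: with the shared core and the benzyl ester unchanged, putting 2-(methylsulfanyl)ethyl in place of isopropyl gives a number 24.7 percentage points lower from compound 1 to compound 3 (beyond the scatter), the first step seen at this position. The effect at the dose given therefore depends on this side chain as well as on the ester end, and of the two side chains compared here, isopropyl gives the higher number. Nothing measured here explains the fall, so it stands only as an observation.

The change brings in a sulfur and lengthens the chain at the same time, so the compounds shown cannot tell these two features apart; a plain butyl chain, which has no sulfur, would separate them. Also open, from the compounds shown here alone, is how this position responds to quite different groups, such as a benzyl group, an amine or a carboxylic acid on the side chain, and whether smaller groups such as methyl keep the number of compound 1.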